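A few compounds are considered here, and "the series" means these few. Any claim that something is new, unique, unknown or untested is made for them only; others in the source may bear on it.

Of the compounds shown here, two with a shared core have been tested so far in an ADME assay on Vero cells (Chlorocebus sabaeus) for cytotoxicity, read by MTT assay, with a stated time of 72 h; on this read-out lower numbers stand for higher toxicity in this test and higher numbers for lower toxicity in this test. Compound 1 `COC(=O)c1cc(-c2cccc(NC(=O)c3ccc(/C=C/C(=O)c4ccc(Cl)cc4)cc3)c2)on1`, which carries 4-chlorophenyl on a carbonyl carbon, gives > 50 ug/mL, and this is a limit of the assay and not a number. Compound 2 `COC(=O)c1cc(-c2cccc(NC(=O)c3ccc(/C=C/C(=O)c4ccc(C)c([N+](=O)[O-])c4)cc3)c2)on1` gives > 80 ug/mL, which is also a limit. Compound 2 therefore stands at a limit only, and no exact number is available in this assay for either compound.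

Within the data shown here, the one measured change, 4-methyl-3-nitrophenyl in place of 4-chlorophenyl on a carbonyl carbon, is a step that the two limits leave unreadable from compound 1 to compound 2. It offers no size to carry forward.

Compound 3 `COC(=O)c1cc(-c2cccc(NC(=O)c3ccc(/C=C/C(=O)c4ccccc4Cl)cc3)c2)on1` has 2-chlorophenyl in place of 4-methyl-3-nitrophenyl on a carbonyl carbon, and the difference is 2-chlorophenyl in place of 4-methyl-3-nitrophenyl on a carbonyl carbon. With only a step that the two limits leave unreadable from compound 1 to compound 2 to go on, no shift in either direction beyond the usual scatter is expected in this assay. The estimated change is an at least 1.1-fold lower number from compound 2 to compound 3 (0.05 log units; that floor lies within the scatter). For compound 3 the expected value is 70 ug/mL, with an estimated range of 30 ug/mL to 150 ug/mL.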

Compound 3, half-maximal cytotoxic concentration: > 25 ug/mL
Compound 3: no number, only a limit (the forecaster's own chance of this, stated with the estimate: 60%); the middle value does not contradict the limit.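

Compound 3 gives > 25 ug/mL in this assay, which is a limit of the assay and not a number. Compound 1 and compound 2 also stand only at limits, and none of the steps among these three compounds can be read. The compounds shown leave open what exact value any of them has, and whether changing the group on the carbonyl carbon shifts that value at all.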